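Changing the chain of compound 2

The compounds below may be only part of what the source reports. "The series", "measured", "known", "first", "only" and "open" are said of these compounds alone.

Values so far in a functional assay for inhibition, with Homo sapiens as the target; on this read-out lower numbers stand for an effect already at smaller amounts and higher numbers for an effect only at larger amounts of compound:
Compound 1 `O=C1CCC(c2ccc(NC(=O)CCCl)cc2)=NN1` gives 0.98 ug/mL
Compound 2 `O=C1CCC(c2ccc(NC(=O)CCCCl)cc2)=NN1` gives > 46.4 ug/mL, which is a limit

Compound 2 has no number of its own and stands only at the limit of > 46.4 ug/mL in this assay, at which 1 of the 2 values shown sits. Among the compounds with values here, the one measured step, an at least 47-fold higher number from compound 1 to compound 2 (1.67 log units; beyond the scatter), is large and beyond the scatter, and it falls on the same chain that changes next. Compound 3 `CCC(C)NCC(=O)Nc1ccc(C2=NNC(=O)CC2)cc1` keeps the shared core and differs from compound 2 as follows: (sec-butyl)amino in place of 2-chloroethyl on a saturated chain carbon bound to a carbonyl carbon. In words, this is (sec-butyl)amino in place of 2-chloroethyl on a saturated chain carbon bound to a carbonyl carbon. Within the data shown here, no measured compound carries an amine there, so the only guide is the large step of an at least 47-fold higher number from compound 1 to compound 2 (1.67 log units; beyond the scatter), and a sizeable move towards lower numbers is expected, though with wide uncertainty. The expected change is an at least 9.2-fold lower number from compound 2 to compound 3 (0.96 log units; beyond the scatter). The estimate for compound 3 is 5 ug/mL, with an expected range from 0.6 ug/mL to 40 ug/mL.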

Compound 3, half-maximal effective concentration: about 21.5 ug/mL
Compound 3: middle estimate off by 4.3-fold (0.63 log units), on the low side; measured number inside the range.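

Putting (sec-butyl)amino in place of 2-chloroethyl on a saturated chain carbon bound to a carbonyl carbon brings back a measurable value in this assay, with an at least 2.1-fold lower number from compound 2 to compound 3 (0.33 log units; beyond the scatter). That step is only a bound, since one end of it is a limit and not a number: the limit of > 46.4 ug/mL in this assay, at which 1 of the 3 values shown sits. The amine still falls short of the chloromethyl chain, with a 22-fold higher number from compound 1 to compound 3 (1.34 log units; beyond the scatter), so a chain without chlorine can give an effect at this position, but here only at larger amounts.

On these data alone, it remains open whether the value follows the amine itself or the sec-butyl group on it, which a primary amine, dimethylamino or piperidine at the same place would separate. Also open, as far as these compounds go, is how much the value of the chloromethyl chain depends on its chlorine, which a bromomethyl or plain methyl group there would test.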